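Chain-end variation on the shared core: toward compound 4

The source may hold more compounds than are shown below. What is called first, only, known or untested is meant among the compounds shown, and "the series" means these compounds.

Among the measured compounds shown here, compound 3 `O=C(O)CCCCOc1ccc2c(=O)c(-c3ccc(O)cc3)coc2c1` gives 100 nM in an assay (Cricetulus griseus) for inhibition of aldehyde dehydrogenase, mitochondrial (Homo sapiens) (a higher number here means a weaker inhibitor, a lower number a stronger inhibitor), the lowest of the three numbers measured so far. Compound 2 `O=c1c(-c2ccc(O)cc2)coc2cc(OCCCCCCO)ccc12` gives 120 nM; the step of a 1.2-fold lower number from compound 2 to compound 3 (0.08 log units; within the scatter) lies within the scatter, so the two cannot be ordered. Compound 1 `CCOC(=O)CCCCOc1ccc2c(=O)c(-c3ccc(O)cc3)coc2c1` gives 240 nM; the step of a 2.4-fold lower number from compound 1 to compound 3 (0.38 log units; beyond the scatter) is beyond the scatter, though modest, while a 2.0-fold lower number from compound 1 to compound 2 (0.30 log units; within the scatter) stays within it.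

Compound 4 `CCCCCCOc1ccc2c(=O)c(-c3ccc(O)cc3)coc2c1` differs from compound 3 in one place: ethyl in place of carboxy on a saturated chain carbon, four bonds along the chain from an oxygen on an aromatic ring. Every measured step alters the same end of the chain: a 2.4-fold lower number from compound 1 to compound 3 (0.38 log units; beyond the scatter) was the largest, and a 1.2-fold lower number from compound 2 to compound 3 (0.08 log units; within the scatter) and a 2.0-fold lower number from compound 1 to compound 2 (0.30 log units; within the scatter) remained within the scatter. Changes at this position have so far moved the half-maximal inhibitory concentration only modestly, and no measured compound carries an ethyl end with no donor and no acceptor there. A small upward move, or none beyond the scatter, is expected. For compound 4 the expected step is a 2.0-fold higher number from compound 3 to compound 4 (0.30 log units; within the scatter). Compound 4 is estimated to give 200 nM, in the range 80 nM to 500 nM.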

Compound 4, half-maximal inhibitory concentration: 1500 nM
The estimate for compound 4 lay 7.5-fold (0.88 log units) below the measured number; the whole stated range lies below it.
By their numbers in this assay, from the lowest: compounds 3, 2 and 1 (each within the scatter of the next, the first and the last beyond it); then compound 4.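

In this assay, this end of the chain proves far from indifferent: the oxygen-bearing ends differ from one another by modest steps at most, whereas the ethyl end, with 0 hydrogen-bond donors and 0 hydrogen-bond acceptors, gives a 15-fold higher number from compound 3 to compound 4 (1.18 log units; beyond the scatter) and a 13-fold higher number from compound 2 to compound 4 (1.10 log units; beyond the scatter). The ethoxycarbonyl end also keeps a lower number than the ethyl end, with a 6.3-fold higher number from compound 1 to compound 4 (0.80 log units; beyond the scatter), so all three oxygen-bearing ends shown stand clear of it, though this step is the smallest of the three. No evidence on hand accounts for the rise.

On these data alone, whether any polar atom at the chain end would serve remains open, since a terminal amine, a primary amide or a methyl ether could give a different answer. As far as these compounds go, how the chain length interacts with the end group also remains open, for instance a longer chain ending in a carboxylic acid.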